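Fluoro to Hydrogen on Two Different Cores

The source may hold more compounds than are shown below. What is called first, only, known or untested is meant among the compounds shown, and "the series" means these compounds.

Compound 1 `Cc1cnc(Nc2ccc(S(C)(=O)=O)cc2)nc1Nc1nc2ccccc2s1`: 6550 nM
Compound 2 `Cc1cnc(Nc2ccc(S(C)(=O)=O)cc2)nc1Nc1nc2ccc(F)cc2s1`: 3260 nM
Compound 3 `COc1ccc2nc(Nc3nc(Nc4ccc(S(N)(=O)=O)cc4)ncc3F)sc2c1`: > 50000 nM

In a functional assay on MCF7 cells (Homo sapiens) for antiproliferative activity, read by MTT assay, with a stated time of 48 h (on this read-out higher numbers stand for weaker inhibition and lower numbers for stronger inhibition), compound 2 and compound 1 are linked by the step of a 2.0-fold higher number from compound 2 to compound 1 (0.30 log units; within the scatter), which goes with the change (hydrogen in place of fluoro on an aromatic carbon). For compound 3 the assay reports only a limit, > 50000 nM. One of the three measured values sits at this limit (the limit of > 50000 nM in this assay, at which 1 of the 3 values shown sits). How the core of compound 3 differs from the core of compound 2 is not broken down here.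

Compound 4 `COc1ccc2nc(Nc3ccnc(Nc4ccc(S(N)(=O)=O)cc4)n3)sc2c1` is not yet measured. It differs from compound 3 by hydrogen in place of fluoro on an aromatic carbon. This is the same kind of change as from compound 2 to compound 1, but the place is different: here the aromatic carbon sits on a six-membered aromatic ring with 2 nitrogen, ortho to a large group, two atoms from the ring nitrogen and para to a large group, whereas before it sat on a six-membered aromatic ring of carbon only, part of a fused or bridged system of two rings, meta and para to a fused ring. Because the earlier step of a 2.0-fold higher number from compound 2 to compound 1 (0.30 log units; within the scatter) lay within the scatter, a similarly small step is expected from compound 3 to compound 4, estimated at a step that the limit leaves unreadable from compound 3 to compound 4. Compound 4 is therefore expected to remain at or beyond the limit, with an estimated value of 90000 nM.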

Compound 4, half-maximal inhibitory concentration: 11000 nM
Compound 4: middle estimate off by 8.2-fold (0.91 log units), on the high side; measured number outside the range, below it.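

In this assay, putting hydrogen in place of fluoro gives an at least 4.5-fold lower number from compound 3 to compound 4 (0.65 log units; beyond the scatter). The value of compound 3, > 50000 nM, is a limit and not a number. These two pairs show that the change does not have one fixed effect across the two cores, but they give no reason for the difference and no rule for other cores: the same change on two cores in this assay, a 2.0-fold higher number (0.30 log units; within the scatter) from compound 2 to compound 1 and an at least 4.5-fold lower number (0.65 log units; beyond the scatter) from compound 3 to compound 4, at least 9.1-fold (0.96 log units) apart, beyond the scatter of two such steps

As far as these compounds go, it remains open whether the difference follows the place of the change, on the ring with 2 nitrogen rather than the ring of carbon only, or other parts of the cores. From the compounds shown here alone, it is also open how a chlorine atom or an amine at the place of the fluoro in compound 3 would read.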